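Swapping a pyrazole for a thiadiazole on a salicylate core

The source may hold more compounds than are shown below. What is called first, only, known or untested is meant among the compounds shown, and "the series" means these compounds.

Measured in a functional assay on the whole organism for inhibition, with Rattus norvegicus as the target, read by paw edema; a higher number here means that more compound is needed for the effect, a lower number that less compound is needed:
compound 1 `CC(=O)Oc1ccc(-n2cccc2)cc1C(=O)O`: 42 mg/kg
compound 2 `O=C(O)c1cc(-c2cc[nH]n2)ccc1O`: a limit of the assay, > 250 mg/kg
compound 3 `O=C(O)c1cc(-c2ccccn2)ccc1O`: 200 mg/kg

Compound 2 stands apart from the other two in that no number was obtained for it in this assay: only a limit. The value > 250 mg/kg for compound 2 is the limit of the assay, as stated in the limit of > 250 mg/kg in this assay, at which 1 of the 3 values shown sits. Compound 1 gives 42 mg/kg and compound 3 gives 200 mg/kg, both numbers rather than limits.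

Compound 4 `O=C(O)c1cc(-c2csnn2)ccc1O` has not yet been measured. It differs from compound 2 in one place: 1,2,3-thiadiazol-4-yl in place of 1H-pyrazol-3-yl on an aromatic carbon. Going by the values given here, no measured pair in this set differs in one place only, so no step between known compounds can be used as a guide, and nothing in the data ties this ring swap to a change in paw edema.

Given that compound 2 returned only a limit in this assay, compound 4 is expected to land near that same edge, with a fair chance that it too gives only a limit. The expected step from compound 2 to compound 4 is an at least 1.1-fold lower number from compound 2 to compound 4 (0.05 log units; that floor lies within the scatter), that is, none beyond the scatter. For compound 4 the estimate is 220 mg/kg, ranging from 80 mg/kg to 600 mg/kg.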

Compound 4, dose for half-maximal effect: > 200 mg/kg
Compound 4 was reported as a limit; the forecaster's own chance of this, stated with the estimate: 50%; the middle value does not contradict the limit.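

Going by these compounds alone, compound 2 and compound 4 each give only a limit of the assay in this assay, not a number, and no step from one to the other can be read. The compounds shown leave open whether 1,2,3-thiadiazol-4-yl in place of 1H-pyrazol-3-yl changes the dose needed in this assay at all, and in which direction.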